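The compounds below may be only part of what the source reports. "The series", "measured", "known", "first", "only" and "open" are said of these compounds alone.

Measured so far:
- compound 1 `CCCc1nc(-c2ccccc2)c(CNCCN2CCN(C(c3ccccc3)c3ccccc3)CC2)o1`: 7470 nM
- compound 2 `CCCc1nc(-c2ccccc2)c(CNCCCN2CCN(c3ccc(F)cc3)CC2)o1`: 3210 nM

In an assay on HEK293 cells for inhibition of Voltage-dependent T-type calcium channel subunit alpha-1G (Homo sapiens), read by patch clamp (a higher number here means a weaker inhibitor, a lower number a stronger inhibitor), compound 2 gives 3210 nM, the lowest of the two numbers in hand. Its nearest neighbour, compound 1, gives 7470 nM, a higher number that lies beyond the scatter; the two structures differ in several places at once, so no single-change step can be read from this pair. Going by the values given here, no step between measured compounds that differ in one place is available, and nothing yet shows how a substituent on the terminal aromatic ring moves the read-out in this assay.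

Compound 3 `CCCc1nc(-c2ccccc2)c(CNCCCN2CCN(c3ccc(C)cc3)CC2)o1` is the next compound; it differs from compound 2 by methyl in place of fluoro on an aromatic carbon. Among the compounds with values here, with no measured step of this kind to lean on, the step of a 1.1-fold lower number from compound 2 to compound 3 (0.03 log units; within the scatter) is expected to be small, within the scatter, in either direction. Compound 3 is therefore estimated at 3000 nM, with a range from 1200 nM to 7500 nM.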

Compound 3, half-maximal inhibitory concentration: 130000 nM
Beside the measured number, compound 3's estimate is 43-fold (1.64 log units) below it; measured number above the stated range.
By their numbers in this assay, from the lowest: compound 2; then compound 1; then compound 3.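

The terminal aromatic ring gives the series its first single-change reading: in this assay, 4-fluorophenyl to 4-methylphenyl is a 40-fold higher number from compound 2 to compound 3 (1.61 log units; beyond the scatter). An exchange of one heavy atom for one heavy atom, with no ring, hydrogen-bond donor, hydrogen-bond acceptor or net charge entering or leaving, is enough to move the read-out far beyond the scatter, so this place on the ring, para to a large group, is not indifferent to what it carries. Nothing in hand accounts for the size of this step.

An unsubstituted phenyl, or chloro or methoxy at this place, would show whether fluoro lowers the number, methyl raises it, or both apply. From the compounds shown here alone, whether the step carries over to a longer linking chain also remains open.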